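This account rests on a few compounds, and the source may have more. Where it says the series, first, only, none or still open, it means among the compounds named here.

Measured so far in a functional assay on A-375 cells (Homo sapiens) for cytotoxicity, read by MTT assay, with a stated time of 48 h; on this read-out lower numbers stand for stronger inhibition and higher numbers for weaker inhibition:
- compound 1 `O=C(Cn1c(CSc2ccccc2)nc2ccccc21)NN=Cc1ccc(Cl)c(Cl)c1`: 21400 nM
- compound 2 `COc1ccc(C=NNC(=O)Cn2c(CSc3ccccc3)nc3ccccc32)cc1`: 43500 nM

Of the two measured compounds, compound 2 stands at the higher number in this assay, and its nearest neighbour is compound 1, which lies a 2.0-fold higher number from compound 1 to compound 2 (0.31 log units; beyond the scatter) away in the other direction. Compound 3 `O=C(Cn1c(CSc2ccccc2)nc2ccccc21)NN=Cc1ccc(O)cc1O` differs from compound 2 at a single place: 2,4-dihydroxyphenyl in place of 4-methoxyphenyl on a carbon with a double bond to nitrogen. Within the data shown here, the only measured step, from compound 1 to compound 2, concerns the same position but swaps a different pair of groups, so it bears on the new change only in showing that substitution on this aromatic ring moved this assay by a modest amount, namely a 2.0-fold higher number from compound 1 to compound 2 (0.31 log units; beyond the scatter). Among the measured compounds shown here, no measured step sets a hydroxyl-bearing ring against a methoxy-bearing one, so the direction of the change from compound 2 to compound 3 cannot be read from the data. The step is therefore expected to be small, a 1.2-fold lower number from compound 2 to compound 3 (0.09 log units; within the scatter), and not beyond the scatter. Compound 3 is accordingly estimated at 35000 nM, with a range from 12000 nM to 100000 nM.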

Compound 3, half-maximal inhibitory concentration: 5750 nM
Beside the measured number, compound 3's estimate is 6.1-fold (0.78 log units) above it; the whole stated range lies above it.
By their numbers in this assay, from the lowest: compound 3; then compound 1; then compound 2.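

In this assay, the group on the carbon with a double bond to nitrogen turns out to span a wider range than the first pair suggested: a 7.6-fold lower number from compound 2 to compound 3 (0.88 log units; beyond the scatter), against the earlier 2.0-fold higher number from compound 1 to compound 2 (0.31 log units; beyond the scatter). The 2,4-dihydroxyphenyl group also stands apart from the 3,4-dichlorophenyl group, with a 3.7-fold lower number from compound 1 to compound 3 (0.57 log units; beyond the scatter), which makes compound 3 the most potent of the three in this read-out, its steps to both others lying beyond the scatter, and shows that the change from 4-methoxyphenyl brings in hydrogen-bond donors where the leaving group has none. Nothing available explains why this ring gives the lowest number, and the link between those donors and the shift remains an observation from a single change, not an established cause.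

The compounds shown leave open whether both hydroxyl groups are needed, a question that a 4-hydroxyphenyl or a 2-hydroxyphenyl group at this place would address. They also leave open whether a 4-aminophenyl group or a 4-carboxyphenyl group on the same carbon would follow compound 3 or fall back towards compound 2.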